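The source may report more compounds than this note shows. Statements on the series, on what has been measured and on what is new or still open speak of the compounds shown alone.

Compound 1 `CCO/N=C/c1c(N)ncnc1Oc1ccc2[nH]c(C)cc2c1F` gives the strongest number of the three in a functional assay on HeLa cells (Homo sapiens) for antiproliferative activity (on this read-out higher numbers stand for weaker inhibition and lower numbers for stronger inhibition), at 32 nM. Two neighbours were measured in this assay: compound 2 `Cc1cc2c(F)c(Oc3ncnc(N)c3/C=N/OCCCO)ccc2[nH]1` at 362 nM, and compound 3 `CNCCO/N=C/c1c(N)ncnc1Oc1ccc2[nH]c(C)cc2c1F` at 2010 nM; the change from compound 1 was an 11-fold higher number from compound 1 to compound 2 (1.05 log units; beyond the scatter) and a 63-fold higher number from compound 1 to compound 3 (1.80 log units; beyond the scatter). Compound 4 `CCCCO/N=C/c1c(N)ncnc1Oc1ccc2[nH]c(C)cc2c1F` differs from compound 1 in one place: ethyl in place of hydrogen on a saturated chain carbon, two bonds along the chain from an oxygen on an unsaturated carbon. Both measured steps added a group carrying a hydrogen-bond donor at this position and weakened inhibition, while the ethyl carries none, so they bear on compound 4 only loosely. The expected step is therefore small, on the weaker side, as a 1.9-fold higher number from compound 1 to compound 4 (0.27 log units; within the scatter). Compound 4 is estimated at 60 nM, within a range of 20 nM to 200 nM.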

Compound 4, half-maximal inhibitory concentration: 607 nM
Compound 4: the middle estimate sits 10-fold (1.01 log units) below what was measured; the whole stated range lies below it.
By their numbers in this assay, from the lowest: compound 1; then compounds 2 and 4 (each within the scatter of the next); then compound 3.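

In this assay, for the compounds shown here, ethyl in place of hydrogen on this chain carbon gives a 19-fold higher number from compound 1 to compound 4 (1.28 log units; beyond the scatter), so inhibition weakens here even when the added group has no hydrogen-bond donor, which the earlier steps could not show. With a 1.7-fold higher number from compound 2 to compound 4 (0.22 log units; within the scatter), methyl and hydroxy at the chain end cannot be told apart, while a 3.3-fold lower number from compound 3 to compound 4 (0.52 log units; beyond the scatter) leaves the methylamino chain the weakest of the set. No measurement shown here bears on the reason for these losses. As far as these compounds go, whether a propoxy chain already weakens inhibition, or a methoxy group keeps it, stays open.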